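The compounds below may be only part of what the source reports. "The series", "measured", "known", "first", "only" and "open" are said of these compounds alone.

Three esters built on the same core have been measured in a functional assay on MCF7 cells (Homo sapiens) for inhibition, read by MTT assay, with a stated time of 72 h; a lower number here means a stronger inhibitor, a higher number a weaker inhibitor. Compound 1 `Cc1ccccc1C(=O)OC1(C(=O)Nc2ccc([N+](=O)[O-])cc2)CCCCC1` gives 516 nM. Compound 2 `O=C(OC1(C(=O)Nc2ccc([N+](=O)[O-])cc2)CCCCC1)c1ccc([N+](=O)[O-])cc1` gives 8.7 nM, and compound 3 `O=C(OC1(C(=O)Nc2ccc([N+](=O)[O-])cc2)CCCCC1)C(O)c1ccccc1` gives 5.01 nM. Compound 3 thus carries the lowest number of the three; its nearest neighbour is compound 2, since a 1.7-fold lower number from compound 2 to compound 3 (0.24 log units; within the scatter), while at the far end a 100-fold lower number from compound 1 to compound 3 (2.01 log units; beyond the scatter). Compound 4 `CC(=O)Oc1ccccc1C(=O)OC1(C(=O)Nc2ccc([N+](=O)[O-])cc2)CCCCC1` has not been measured yet. It differs from compound 3 in one place: 2-acetoxyphenyl in place of hydroxy(phenyl)methyl on a carbonyl carbon. Among the compounds with values here, no measured step makes exactly this change, but two of them bear on it. Compound 4 carries a substituted phenyl ring on the carbonyl carbon, as compound 1 does, and a 100-fold lower number from compound 1 to compound 3 (2.01 log units; beyond the scatter) was large. Compound 2 also carries a substituted phenyl on that carbon, yet a 1.7-fold lower number from compound 2 to compound 3 (0.24 log units; within the scatter) shows compound 2 sitting close to compound 3. The new group could therefore land anywhere between these two outcomes, and the expected step is toward a higher number, of moderate size, a 30-fold higher number from compound 3 to compound 4 (1.48 log units; beyond the scatter). For compound 4 in this assay the estimate is 150 nM, expected to fall within a range from 25 nM to 900 nM.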

Compound 4, half-maximal inhibitory concentration: 16.9 nM
Compound 4: middle estimate off by 8.9-fold (0.95 log units), on the high side; measured number outside the range, below it.
By their numbers in this assay, from the lowest: compounds 3, 2 and 4 (each within the scatter of the next, the first and the last beyond it); then compound 1.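

In this assay the ring on this carbonyl carbon proves far more sensitive to its substituent than compound 1 alone suggested: acetoxy in place of methyl on an aromatic carbon gives a 31-fold lower number from compound 1 to compound 4 (1.48 log units; beyond the scatter) and brings that ring into the low range of the series. A substituted phenyl ring at this place is therefore not tied to a high number, since a 1.9-fold higher number from compound 2 to compound 4 (0.29 log units; within the scatter) shows two differently substituted rings that cannot be told apart, while a 3.4-fold higher number from compound 3 to compound 4 (0.53 log units; beyond the scatter) is only a modest step away from the hydroxy(phenyl)methyl group. No evidence is available on why these groups give these numbers.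

The compounds shown leave open how other groups on the phenyl ring would behave, such as a free hydroxy group, a methoxy group, an amine or a carboxylic acid in place of the acetoxy group. They also leave open whether a plain phenyl ring with no substituent would read like compound 1 or like compound 4, and so whether methyl or acetoxy is the group that sets the gap between them.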